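Swapping a cyano-bearing phenyl for a chlorophenyl

The compounds below may be only part of what the source reports. "The series", "measured", "known", "first", "only" and "open" are said of these compounds alone.

Compound 1 `CC/C(=C(/c1ccc(/C=C/C(=O)O)cc1)c1cc2ccccc2[nH]1)c1ccccc1`: 108 nM
Compound 2 `CC/C(=C(/c1ccc(/C=C/C(=O)O)cc1)c1cc2ccccc2[nH]1)c1ccccc1C`: 33 nM
Compound 3 `CC/C(=C(/c1ccc(/C=C/C(=O)O)cc1)c1cc2ccccc2[nH]1)c1ccccc1C#N`: 9 nM

In a functional assay on MCF7 cells (Homo sapiens) for inhibition (a lower number here means a stronger inhibitor, a higher number a weaker inhibitor), compound 3 gives the lowest number of the three measured compounds; the two steps that lead down to it are a 3.7-fold lower number from compound 2 to compound 3 (0.56 log units; beyond the scatter) and a 12-fold lower number from compound 1 to compound 3 (1.08 log units; beyond the scatter). Compound 4 `CC/C(=C(/c1ccc(/C=C/C(=O)O)cc1)c1cc2ccccc2[nH]1)c1ccc(Cl)cc1` differs from compound 3 by 4-chlorophenyl in place of 2-cyanophenyl on a double-bonded chain carbon bound to a double-bonded chain carbon and a saturated chain carbon. Among the measured compounds shown here, no measured step covers this exact swap. The nearest evidence is the step from compound 1 to compound 3 a 12-fold lower number from compound 1 to compound 3 (1.08 log units; beyond the scatter), where introducing the cyano group gave a large gain; taking it away, and placing a chlorine instead, is therefore expected to move the number back up toward compound 1, as a 6.7-fold higher number from compound 3 to compound 4 (0.82 log units; beyond the scatter). Compound 4 is expected to give 60 nM in this assay, within 20 nM to 200 nM.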

Compound 4, half-maximal inhibitory concentration: 343 nM
The estimate for compound 4 lay 5.7-fold (0.76 log units) below the measured number; measured number above the stated range.
By their numbers in this assay, from the lowest: compound 3; then compound 2; then compound 1; then compound 4.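

In this assay, a group added to the phenyl on this double-bonded chain carbon does not always lower the number: chloro in place of hydrogen gives a 3.2-fold higher number from compound 1 to compound 4 (0.50 log units; beyond the scatter) and is the only such change shown that raises it. The 4-chlorophenyl also falls well behind both 2-substituted phenyls, with a 10-fold higher number from compound 2 to compound 4 (1.02 log units; beyond the scatter) and a 38-fold higher number from compound 3 to compound 4 (1.58 log units; beyond the scatter) as the two steps. Nothing at hand explains these steps.

On these data alone, it remains open whether the chlorine itself or its place on the ring accounts for the rise. A 2-chlorophenyl or a 4-cyanophenyl on this carbon would separate the two.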